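Swapping the Amide Aryl Group: From Nitrophenyl to Methylphenyl

The compounds below may be only part of what the source reports. "The series", "measured", "known", "first", "only" and "open" are said of these compounds alone.

Compound 3 `O=C(Nc1ccc([N+](=O)[O-])cc1)c1c(O)c2cccnc2n(-c2ccccc2)c1=O` was tested in a functional assay on the whole organism for inhibition, with Rattus norvegicus as the target, read by cytopathic effect and paw edema, at a dose of 100 mg/kg by the oral route (a lower number here means less inhibition, a higher number more inhibition at the dose given (going by the name of the read-out)), where compound 3 gave -25.8%. Among the three measured compounds, compound 3 stands second highest; its nearest neighbour is compound 2 `O=C(NN1CCOCC1)c1c(O)c2cccnc2n(-c2ccccc2)c1=O`, which gave -26.2%, the difference being a number 0.4 percentage points higher from compound 2 to compound 3 (within the scatter). The furthest is compound 1 `CCCCNC(=O)c1c(O)c2cccnc2n(-c2ccccc2)c1=O`, which gave 20.4%, the gap being a number 46.2 percentage points lower from compound 1 to compound 3 (beyond the scatter).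

Compound 4 `Cc1ccccc1NC(=O)c1c(O)c2cccnc2n(-c2ccccc2)c1=O` differs from compound 3 in one place: 2-methylphenyl in place of 4-nitrophenyl on an amide-type nitrogen. Among the compounds with values here, no measured step exchanges one aryl group for another on this nitrogen. The two large steps, a number 46.6 percentage points lower from compound 1 to compound 2 (beyond the scatter) and a number 46.2 percentage points lower from compound 1 to compound 3 (beyond the scatter), both replace butyl, while the step of a number 0.4 percentage points higher from compound 2 to compound 3 (within the scatter) shows that morpholin-4-yl and 4-nitrophenyl give numbers within the scatter of each other. Since compound 4 keeps an aryl group on the amide-type nitrogen, the expected step of a number 15.8 percentage points higher from compound 3 to compound 4 (beyond the scatter) is small, possibly not beyond the scatter, with a modest rise allowed. Compound 4 is therefore expected to give about -10%, within a range from -38% to 20%.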

Compound 4, a percentage reported as inhibition, in the whole organism at one dose (the size of the read-out at that dose, not a potency): 9.8%
For compound 4 the middle estimate is 19.8 percentage points below the measured one, within the range that was stated.
By their numbers in this assay, from the lowest: compounds 2 and 3 (each within the scatter of the next); then compound 4; then compound 1.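

Exchanging one aryl group for another on the amide-type nitrogen proves to be a large change in this assay (a number 35.6 percentage points higher from compound 3 to compound 4 (beyond the scatter)), so an aryl group at this position does not by itself set the number. The 2-methylphenyl group also stands clear of morpholin-4-yl (a number 36 percentage points higher from compound 2 to compound 4 (beyond the scatter)), yet it stays modestly short of butyl (a number 10.6 percentage points lower from compound 1 to compound 4 (beyond the scatter)), and so replacing butyl no longer leads to a single low level. Nothing on hand bears on why these groups differ in this way.

The compounds shown do not separate the gain of the methyl group from the loss of the nitro group. Going by these compounds, it also remains open where an unsubstituted phenyl ring or a chain longer than butyl would fall on this nitrogen.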